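The source may report more compounds than this note shows. Statements on the series, on what has been measured and on what is new or still open speak of the compounds shown alone.

Within the data shown here, compound 1 `COc1ccccc1-n1nc(C2CC(C)(C)OC(C)(C)C2)cc1-c1ccnc(Cl)c1` is the weakest of the three compounds measured so far in an assay on HEK293 cells for inhibition of Voltage-dependent N-type calcium channel subunit alpha-1B (Homo sapiens), read by patch clamp, using a membrane potential dye; a higher number here means a weaker inhibitor, a lower number a stronger inhibitor: compound 1 gives 250 nM. Compound 2 `COc1ccccc1-n1nc([C@H]2C[C@@H](C)O[C@@H](C)C2)cc1-c1ccc(Cl)cc1` gives 12 nM, and compound 3 `COc1ccccc1-n1nc(C2CCOC(C)(C)C2)cc1-c1ccc(Cl)cc1` gives 55 nM. Among the measured compounds shown here, the one direct comparison available concerns the oxane ring, not the aromatic group: a 4.6-fold higher number from compound 2 to compound 3 (0.66 log units; beyond the scatter). For the measured compounds named here, compound 1 and compound 3 differ in more than one place, so their two values show only that compound 1 is the weaker of the pair.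

Compound 4 `CCOc1ccc(-c2cc(C3CC(C)(C)OC(C)(C)C3)nn2-c2ccccc2OC)cn1` differs from compound 1 in a single place: 6-ethoxypyridin-3-yl in place of 2-chloropyridin-4-yl on an aromatic carbon. Going by the values given here, no measured pair isolates a change of this aromatic group, so there is no step to lean on for its size or direction. The stronger compounds 2 and 3 carry a different aromatic group from compound 1, but each also carries a different oxane ring, so their values cannot be assigned to the aromatic group alone.

With nothing to point either way, compound 4 is expected to stay close to compound 1, with a 1.3-fold lower number from compound 1 to compound 4 (0.10 log units; within the scatter) as a central guess and a wide spread. For compound 4 in this assay the estimate is 200 nM, expected to fall between 40 nM and 1000 nM.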

Compound 4, half-maximal inhibitory concentration: 44 nM
The estimate for compound 4 lay 4.5-fold (0.66 log units) above the measured number, within the range that was stated.
By their numbers in this assay, from the lowest: compound 2; then compounds 4 and 3 (each within the scatter of the next); then compound 1.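

In this assay, among these compounds, a 5.7-fold lower number from compound 1 to compound 4 (0.75 log units; beyond the scatter) is the first measured change of the aromatic group at this position with the 2-methoxyphenyl and 2,2,6,6-tetramethyloxan-4-yl groups held fixed, and it shows that the group on this aromatic carbon affects the number in its own right, not only the oxane ring. The change has several parts, however: the chlorine leaves, an ethoxy group enters, and the pyridine ring is attached through a different ring carbon, so this single step cannot divide its effect among those three differences. Nothing available here explains why the number falls with this swap.

Going by these compounds, it remains open whether the ethoxy group or the altered attachment of the pyridine ring matters more, a question that a 6-chloropyridin-3-yl group would help to separate, while a 6-methoxypyridin-3-yl group, a longer propoxy chain or an amine at the same ring position would show how far the substituent itself can be varied. Also open, on these data alone, is whether 6-ethoxypyridin-3-yl would give a similar step on the 2,6-dimethyloxan-4-yl ring of compound 2.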